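A Prenyl Group Added to a Weak Pair

The compounds below may be only part of what the source reports. "The series", "measured", "known", "first", "only" and "open" are said of these compounds alone.

Of the compounds shown here, two of a shared core have been measured in a functional assay; a higher number here means a weaker inhibitor, a lower number a stronger inhibitor. Compound 1 `C=CC(C)(C)c1[nH]c2ccc(C[C@@H](O)C(=C)C)cc2c1/C=C1\NC(=O)[C@H](C)NC1=O` gives 75000 nM in this assay. Compound 2 `C=CC(C)(C)c1[nH]c2ccccc2c1/C=C1\NC(=O)C(C)(OC)NC1=O` gives 99000 nM in this assay. Compound 2 has the highest of the two numbers, but its nearest neighbour, compound 1, lies within the scatter, so the two cannot be told apart on these data.

The step under consideration leads from compound 2 to compound 3 `C=CC(C)(C)c1[nH]c2ccc(CC=C(C)C)cc2c1/C=C1\NC(=O)C(C)(OC)NC1=O`, which has not yet been measured. 3-methylbut-2-en-1-yl in place of hydrogen on an aromatic carbon The group enters on an aromatic carbon of a six-membered aromatic ring of carbon only, part of a fused system of two rings.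

For the measured compounds named here, no step between measured compounds is available to calibrate this change. Compound 1 carries a related side chain at that position and gives 75000 nM in this assay, which sits within the scatter of compound 2. The expected step of a 1.7-fold lower number from compound 2 to compound 3 (0.22 log units; within the scatter) is therefore small, leaning toward a slightly lower number. Compound 3 is estimated to give 60000 nM in this assay, with a range from 20000 nM to 180000 nM.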

Compound 3, half-maximal inhibitory concentration: 79000 nM
Compound 3: the middle estimate sits 1.3-fold (0.12 log units) below what was measured; the range from low to high includes it.
By their numbers in this assay, from the lowest: compounds 1, 3 and 2 (each within the scatter of the next).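

For the compounds shown here, this is the first change at this position that can be read on its own, since compound 1 and compound 2 differ in more than one place. Setting 3-methylbut-2-en-1-yl in place of hydrogen on this aromatic carbon gives, in this assay, a 1.3-fold lower number from compound 2 to compound 3 (0.10 log units; within the scatter), so the two compounds cannot be told apart and this group, with no ring and no hydrogen-bond donors or acceptors, brings no measurable gain or loss on the shared core. The position therefore accepts this substituent without a readable shift in this assay, though no measurement is at hand that could explain this result.

What the compounds shown leave open is whether any other group on this aromatic carbon, such as an amine, a carboxylic acid or a longer chain, would produce a step beyond the scatter. They also leave open whether 3-methylbut-2-en-1-yl would behave in the same way if it were the only difference from a partner compound without the methoxy group, a pair that would isolate this step on a second background.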